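The source may hold more compounds than are shown below. What is called first, only, known or untested is meant among the compounds shown, and "the series" means these compounds.

Compound 1, `CC(C)=CCC/C(C)=C/CC1Cc2c(OCc3ccccc3)cc(=O)n(CCCO)c2CC1(C)C`, gives 46.5% in a functional assay on PANC-1 cells (Homo sapiens) for inhibition, read by MTT assay, with a stated time of 24 h, tested at 10 uM; on this read-out lower numbers stand for less inhibition and higher numbers for more inhibition at the one concentration tested (going by the name of the read-out).
Compound 2, `CC(C)=CCC/C(C)=C/COc1cc(=O)n(CCCO)c2c1CC(C/C=C(\C)CCC=C(C)C)C(C)(C)C2`, gives 15.8% in this assay.
Compound 3, `COc1ccccc1NC(=O)Oc1cc(=O)n(CCCO)c2c1CC(C/C=C(\C)CCC=C(C)C)C(C)(C)C2`, gives 53% in this assay.

Among these three, compound 3 holds the highest number. Its lead over compound 1 is slight, a number 6.5 percentage points higher from compound 1 to compound 3 (within the scatter), and lies within the scatter, so the two cannot be ranked against each other; its lead over compound 2, a number 37.2 percentage points higher from compound 2 to compound 3 (beyond the scatter), is large and beyond the scatter.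

Compound 4, `CC(C)=CCC/C(C)=C/CC1Cc2c(OC(=O)Nc3ccccc3F)cc(=O)n(CCCO)c2CC1(C)C`, keeps the whole of compound 3 except for one change: fluoro in place of methoxy on an aromatic carbon. Going by the values given here, none of the measured steps touches this position. The step of a number 30.7 percentage points lower from compound 1 to compound 2 (beyond the scatter) changes the group on the oxygen of the core, and the steps of a number 6.5 percentage points higher from compound 1 to compound 3 (within the scatter) and a number 37.2 percentage points higher from compound 2 to compound 3 (beyond the scatter) both bring the carbamoyl onto that oxygen; the substituent on the carbamoyl's own aromatic ring is never varied. Among the compounds with values here, with no precedent, the step from compound 3 to compound 4 is expected to stay within the scatter, a number 3 percentage points lower from compound 3 to compound 4 (within the scatter). Compound 4 is therefore estimated at 50% in this assay, between 35% and 65%.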

Compound 4, a percentage reported as inhibition, at one concentration (the size of the read-out at that concentration, not a potency): 71.6%
The estimate for compound 4 lay 21.6 percentage points below the measured number; the measured number lies above the stated range.
By their numbers in this assay, from the lowest: compound 2; then compounds 1 and 3 (each within the scatter of the next); then compound 4.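

In this assay, going by these compounds alone, the substituent on the carbamoyl's aromatic ring proves to matter: fluoro in place of methoxy, ortho to a large group, gives a number 18.6 percentage points higher from compound 3 to compound 4 (beyond the scatter), whereas the earlier steps varied only the group on the oxygen of the core. With this ring, the (2-fluorophenyl)carbamoyl group now stands clear of benzyl, at a number 25.1 percentage points higher from compound 1 to compound 4 (beyond the scatter), which the (2-methoxyphenyl)carbamoyl group did not do, and the gap to the 3,7-dimethylocta-2,6-dien-1-yl group widens to a number 55.8 percentage points higher from compound 2 to compound 4 (beyond the scatter). Nothing available explains why this change raises the number.

As far as these compounds go, whether a chloro or a methyl at this same place would match fluoro remains open. So does whether compound 4 also leads on potency, as its number comes from a single concentration.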